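Ester variation in a dihydropyrimidinone series: propyl to cyclobutyl

This account rests on a few compounds, and the source may have more. Where it says the series, first, only, none or still open, it means among the compounds named here.

Measured so far:
compound 1, `CCCOC(=O)C1=C(C)NC(=O)NC1c1ccoc1`: 11%
compound 2, `CCCOC(=O)C1=C(C)NC(=O)NC1c1cccs1`: 32%
compound 3, `CCCOC(=O)C1=C(C)N(C)C(=O)NC1c1ccoc1`: 16%

The read-out throughout is an assay on membranes from HeLa cells for displacement of a labelled ligand from adenosine receptor A3 (Homo sapiens), read by scintillation counting, with a stated time of 180 min, tested at 1 uM; on this read-out higher numbers stand for more inhibition at the one concentration tested (going by the name of the read-out) and lower numbers for less inhibition. Compound 1 gives the lowest of the three numbers: its nearest neighbour is compound 3, a number higher only within the scatter, while compound 2 lies furthest above it. Among the measured compounds shown here, the step of a number 21 percentage points higher from compound 1 to compound 2 (beyond the scatter) is the only change so far that moves the number beyond the scatter; the step of a number 5 percentage points higher from compound 1 to compound 3 (within the scatter) does not.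

The next compound is compound 4, `CC1=C(C(=O)OC2CCC2)C(c2ccoc2)NC(=O)N1`. It differs from compound 1 in one place: cyclobutyl in place of propyl on an oxygen next to a carbonyl group.

Neither measured step touches the ester; one changes the aromatic ring on the saturated ring carbon, the other the amide-type nitrogen. For the measured compounds named here, there is therefore no direct precedent for the ester in this assay, and the only guide is that the single small change at the nitrogen left the number within the scatter of compound 1. On that basis the ester change is expected to give no step beyond the scatter, so that a number 3 percentage points higher from compound 1 to compound 4 (within the scatter) is the expected outcome. Compound 4 is estimated at 14%, with a range from 0% to 32%.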

Compound 4, a percentage reported as inhibition, at one concentration (the size of the read-out at that concentration, not a potency): 1%
Compound 4: middle estimate off by 13 percentage points, on the high side; measured number inside the range.
By their numbers in this assay, from the lowest: compounds 4, 1 and 3 (each within the scatter of the next, the first and the last beyond it); then compound 2.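

Among the compounds shown here, the ester position, untouched by the earlier steps, now has its first reading in this assay: cyclobutyl in place of propyl on an oxygen next to a carbonyl group gives a number 10 percentage points lower from compound 1 to compound 4 (within the scatter), so propoxy to cyclobutyloxy is not resolved on this read-out. A ring of carbon only can therefore replace the open propyl chain here without a step beyond the scatter, although compound 1 at 11% and compound 4 at 1% both sit so low at the one concentration tested that a further loss would be hard to see. The data offer no measured basis for explaining this result.

On these data alone, it remains open whether a benzyl ester, a longer chain such as hexyl, or a carboxylic acid at this position would move the number beyond the scatter of compound 1. As far as these compounds go, it is equally open whether the same propyl to cyclobutyl change would read differently with thiophen-2-yl on the saturated ring carbon, where compound 2 at 32% offers a higher starting point.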